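This account rests on a few compounds, and the source may have more. Where it says the series, first, only, none or still open, it means among the compounds named here.

Measured compounds in a functional assay on DU-145 cells (Homo sapiens) for cytotoxicity, read by MTT assay; a higher number here means a weaker inhibitor, a lower number a stronger inhibitor:
Compound 1 `CC(O)(CS(=O)(=O)c1ccc(Cl)cc1)c1nc(-c2ccc(Cl)cc2)no1` gives > 100000 nM, which is a limit of the assay rather than a number.
Compound 2 `CC(O)(CS(=O)(=O)c1ccc(Cl)cc1)c1nc(-c2ccc(F)c(Cl)c2)no1` gives 35500 nM.
Compound 3 `CC(O)(CS(=O)(=O)c1ccc(Cl)cc1)c1nc(-c2ccccc2)no1` gives > 100000 nM, again a limit of the assay.

Among the compounds with values here, compound 2 thus holds the only real number; the other two values sit at the limit of > 100000 nM in this assay, at which 2 of the 3 values shown sit. Compound 4 `CC(O)(CS(=O)(=O)c1ccc(Br)cc1)c1nc(-c2ccc(F)c(Cl)c2)no1` differs from compound 2 by bromo in place of chloro on an aromatic carbon. Within the data shown here, none of the measured steps touches this position: an at least 2.8-fold lower number from compound 1 to compound 2 (0.44 log units; beyond the scatter), an at least 2.8-fold higher number from compound 2 to compound 3 (0.44 log units; beyond the scatter) and a step that the two limits leave unreadable from compound 1 to compound 3 all alter a different part of the shared core. Among the measured compounds shown here, no measured step therefore bears directly on the change, and an exchange of one halogen for a similar one is expected to give no step beyond the scatter, a 1.2-fold lower number from compound 2 to compound 4 (0.07 log units; within the scatter). Compound 4 is estimated at 30000 nM, in the range 10000 nM to 100000 nM.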

Compound 4, half-maximal inhibitory concentration: 75000 nM
For compound 4 the middle estimate is 2.5-fold (0.40 log units) below the measured one; the measured number falls inside the stated range.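

Within the data shown here, this position, which none of the earlier steps touched, responds to a swap of one halogen for another: in this assay, 4-bromophenyl in place of 4-chlorophenyl gives a 2.1-fold higher number from compound 2 to compound 4 (0.32 log units; beyond the scatter). The change is modest, yet it lies beyond the usual scatter, and compound 4 still gives a real number rather than a limit. This reading rests on a single pair of compounds, and the other values offer no further comparison: the limit of > 100000 nM in this assay, at which 2 of the 4 values shown sit.

As far as these compounds go, how an amine or a methoxy group at this position would compare remains open. So does whether the same swap would give a similar step on a different core.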